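Swapping the isobutoxy anilide for a chloro anilide

A few compounds are considered here, and "the series" means these few. Any claim that something is new, unique, unknown or untested is made for them only; others in the source may bear on it.

Compound 1, `CC(C)COc1ccc(NC(=O)CCCCCCCSc2nnc(Cc3nn(C)c(=O)c4ccccc34)n2C)cc1`, is one of a small set of anilides built on a shared core, measured in an assay on isolated protein (Mus musculus) for inhibition of IL15-IL15 receptor (Homo sapiens), read by resazurin assay, with stated times of 30 min and 2.5 days; a higher number here means a weaker inhibitor, a lower number a stronger inhibitor. Of the two numbers in hand, compound 1 gives the higher one, 4800 nM. Compound 2, `Cn1c(Cc2nn(C)c(=O)c3ccccc23)nnc1S(=O)(=O)CCCCCCCC(=O)Nc1ccc(Br)cc1Br`, gives 1400 nM; the gap between the two lies beyond the usual scatter, though the two compounds differ in more than one place, so no single change can be read from it. Compound 3, `Cn1c(Cc2nn(C)c(=O)c3ccccc23)nnc1SCC(=O)Nc1ccc(Br)cc1Br`, reaches only the limit of this assay, > 30000 nM; this is the limit of > 30000 nM in this assay, at which 1 of the 3 values shown sits, and not a number.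

The compound of interest is compound 4, `Cn1c(Cc2nn(C)c(=O)c3ccccc23)nnc1SCCCCCCCC(=O)Nc1ccc(Cl)cc1`. It keeps the thioether and the chain of compound 1 and differs only at the anilide ring: chloro in place of isobutoxy on an aromatic carbon. Among the compounds with values here, no measured pair in the set isolates this change, so the step from compound 1 to compound 4 is expected to be small, a 1.2-fold lower number from compound 1 to compound 4 (0.08 log units; within the scatter), and not beyond the scatter in either direction. On that basis compound 4 is estimated at 4000 nM in this assay, within a range from 1500 nM to 12000 nM.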

Compound 4, half-maximal inhibitory concentration: 800 nM
For compound 4 the middle estimate is 5.0-fold (0.70 log units) above the measured one, and the stated range ends above it.
By their numbers in this assay, from the lowest: compounds 4 and 2 (each within the scatter of the next); then compound 1. At a limit, above all of these: compound 3.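

Chloro in place of isobutoxy on an aromatic carbon gives a 6.0-fold lower number from compound 1 to compound 4 (0.78 log units; beyond the scatter) in this assay and is the first change in this set that can be read on its own, showing that this place on the anilide ring affects the number. It also shows that isobutoxy, with its 5 heavy atoms and its hydrogen-bond acceptor, is not required at this place, since a single chlorine gives the lower number. Nothing measured here accounts for the size of this step.

From the compounds shown here alone, whether the step comes from gaining chloro or from losing isobutoxy remains open, and a plain hydrogen, a fluoro, a methoxy or an amine at this place could help to separate the two. Also open, going by these compounds, is whether a longer chain would change the result for the 4-chlorophenyl anilide.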